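Carbonate in Place of Methyl Ether on the Side Chain

This account rests on a few compounds, and the source may have more. Where it says the series, first, only, none or still open, it means among the compounds named here.

Compound 2 `COC[C@H]1C[C@@](CC(C)C)(C(=O)O)N(C(=O)c2ccc(C(C)(C)C)c(OC)c2)[C@H]1COC` is known only as a limit: in an ADME assay on Huh-5-2 cells (Homo sapiens) for cytotoxicity, with a stated time of 3 days (on this read-out higher numbers stand for lower toxicity in this test and lower numbers for higher toxicity in this test), compound 2 gives > 120000 nM, a limit of the assay rather than a number. Compound 1 `COC[C@H]1C[C@@](CC(C)C)(C(=O)O)N(C(=O)c2ccc(C(C)(C)C)c(OC)c2)[C@@H]1c1nccs1` gives 200000 nM in this assay. Compound 3 `COC[C@H]1C[C@@](CC(C)C)(C(=O)O)N(C(=O)c2ccc(C(C)(C)C)c(OC)c2)[C@H]1C(=O)OC` also sits at a limit, with > 120000 nM in this assay. For the measured compounds named here, the only measured step, a step that the two limits leave unreadable from compound 2 to compound 3, is therefore unreadable, as the limit of > 120000 nM in this assay, at which 2 of the 3 values shown sit, shows. Compound 4 `COC[C@H]1C[C@@](CC(C)C)(C(=O)O)N(C(=O)c2ccc(C(C)(C)C)c(OC)c2)[C@H]1COC(=O)OC` carries the change (methoxycarbonyl in place of methyl on an oxygen on a saturated carbon). Going by the values given here, no measured step bears on this change, so no shift beyond the usual scatter is expected; the step that the limit leaves unreadable from compound 2 to compound 4 is an estimate of no change. Compound 4 is expected to give about 150000 nM, estimated between 60000 nM and 400000 nM, most likely reported again as a limit.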

Compound 4, half-maximal cytotoxic concentration: > 120000 nM
Compound 4: only a limit was reported; the forecaster's own chance of this, stated with the estimate: 60%; the middle value is on the limit's open side.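

No step can be read among compound 2, compound 3 and compound 4, as all three stop at the same limit of the assay: the limit of > 120000 nM in this assay, at which 3 of the 4 values shown sit.

The compounds shown leave open how far the half-maximal cytotoxic concentrations of these three lie from one another.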